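This account rests on a few compounds, and the source may have more. Where it says the series, first, only, none or still open, it means among the compounds named here.

In a functional assay on HUVEC cells (Homo sapiens), read by scintillation counting and thymidine incorporation, with a stated time of 24 h; a higher number here means a weaker inhibitor, a lower number a stronger inhibitor:
Compound 1 `CCC(C)n1ncn(-c2ccc(N3CCN(c4ccc(OC[C@@H]5CO[C@@](CN6CCNCC6)(c6ccc(Cl)cc6Cl)O5)cc4)CC3)cc2)c1=O`: 608 nM
Compound 2 `CCC(C)n1ncn(-c2ccc(N3CCN(c4ccc(OC[C@@H]5CO[C@@](Cn6cnc(C)n6)(c6ccc(Cl)cc6Cl)O5)cc4)CC3)cc2)c1=O`: 272 nM

Compound 2 holds the lower of the two numbers, with compound 1 its nearest neighbour. Compound 3 `CCC(C)n1ncn(-c2ccc(N3CCN(c4ccc(OC[C@@H]5CO[C@@](Cn6nc(C)nc6C)(c6ccc(Cl)cc6Cl)O5)cc4)CC3)cc2)c1=O` differs from compound 2 by methyl in place of hydrogen on an aromatic carbon, giving 3,5-dimethyl-1H-1,2,4-triazol-1-yl. Among the measured compounds shown here, the only measured step, a 2.2-fold lower number from compound 1 to compound 2 (0.35 log units; beyond the scatter), changed the same side group but replaced piperazin-1-yl, so it does not test this added methyl. No step beyond the scatter is therefore expected in this assay, and no direction can be favoured. The estimate means an expected 1.1-fold higher number from compound 2 to compound 3 (0.03 log units; within the scatter). Compound 3 is expected at 290 nM, within an estimated range of 115 nM to 720 nM.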

Compound 3, half-maximal inhibitory concentration: 221 nM
Beside the measured number, compound 3's estimate is 1.3-fold (0.12 log units) above it; the range from low to high includes it.
By their numbers in this assay, from the lowest: compounds 3 and 2 (each within the scatter of the next); then compound 1.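

In this assay the added methyl, on the aromatic carbon between two ring nitrogen atoms, gives a 1.2-fold lower number from compound 2 to compound 3 (0.09 log units; within the scatter) and so leaves the number unchanged within the scatter. Against piperazin-1-yl, the 3,5-dimethyl-1H-1,2,4-triazol-1-yl group gives a 2.8-fold lower number from compound 1 to compound 3 (0.44 log units; beyond the scatter) as a second step beyond the scatter, so both triazolyl groups now stand on the lower side of compound 1. No measurement shown here explains either step.

On these data alone, it remains open whether a longer chain such as propyl, or an amine, on this same carbon would keep the number in this range.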